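This account rests on a few compounds, and the source may have more. Where it says the series, first, only, none or still open, it means among the compounds named here.

Compound 1 `CCCCCCCCCCn1cc(-c2nc3ccccc3cc2C)nn1` in a functional assay on U-937 cells (Homo sapiens) for cytotoxicity, read by MTT assay, with a stated time of 24 h (a higher number here means a weaker inhibitor, a lower number a stronger inhibitor), gives > 100 ug/mL, which is a limit of the assay and not a number.
Compound 2 `Cc1cc2ccccc2nc1-c1cn(-c2ccc(F)cc2)nn1` in this assay gives 65.6 ug/mL.

Compound 1 therefore stands only at the top end of what this assay resolves, as the limit of > 100 ug/mL in this assay, at which 1 of the 2 values shown sits, states; its true value is not known beyond that. Compound 2 is the one measured number in the set, and no step between compound 1 and compound 2 is defined, since they differ in more than one place, so the two values are simply shown side by side.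

Compound 3 `CCCCCCCCCCn1cc(-c2nc3ccccc3cc2CCC)nn1` differs from compound 1 by ethyl in place of hydrogen on a saturated chain carbon bound to an aromatic carbon; otherwise the shared core and the decyl chain are kept. For the measured compounds named here, no measured step of this kind exists, so the expectation rests on compound 1 alone. Since compound 1 already sits at the limit > 100 ug/mL, no step beyond the scatter is expected for a step that the limit leaves unreadable from compound 1 to compound 3, and in either direction a modest shift would most likely remain hidden behind the limit. Compound 3 is accordingly expected to give about 120 ug/mL in this assay, with a plausible range from 45 ug/mL to 320 ug/mL, most probably reported again as a limit.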

Compound 3, half-maximal inhibitory concentration: 26.6 ug/mL
The estimate for compound 3 lay 4.5-fold (0.65 log units) above the measured number; the measured number lies below the stated range.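

In this assay, the saturated chain carbon bound to an aromatic carbon proves to be a position that responds: with the shared core and the decyl chain kept, ethyl in place of hydrogen (methyl to propyl) gives an at least 3.7-fold lower number from compound 1 to compound 3 (0.57 log units; beyond the scatter), a step beyond the scatter. The earlier compounds shown here could not show this, since compound 1 and compound 2 differ in more than one place and no step between them could be read, whereas compound 3 gives 26.6 ug/mL, a measured number in a series that otherwise holds a single one. For compound 1 the reading is a limit and not a number, so the size of the step is a minimum and its true size stays unknown: the limit of > 100 ug/mL in this assay, at which 1 of the 3 values shown sits.

One step cannot say whether the number keeps falling as the chain at this position grows, or whether a longer chain such as butyl, or an amine or a carboxylic acid at the same place, would move it in the same direction. On these data alone, it also stays open whether the same change made on compound 2 would give a step of like size, since only the decyl pair speaks to this position.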